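From amide to free acid, with both limits unreadable

The source may hold more compounds than are shown below. What is called first, only, known or untested is meant among the compounds shown, and "the series" means these compounds.

Compound 2 `C=CC1=C(C(=O)NCc2ccc(Cl)cc2)C(c2ccc(OC)c(OC)c2)OC1` carries a (4-chlorobenzyl)amino group on its carbonyl carbon. In a functional assay on HeLa cells (Homo sapiens) for cytotoxicity, read by MTT assay, with a stated time of 24 h (a higher number here means a weaker inhibitor, a lower number a stronger inhibitor), compound 2 gives only a limit, > 100000 nM. Compound 1 `C=CC1=C(C(=O)NCc2ccccc2)C(c2ccc(OC)c(OC)c2)OC1` likewise gives only a limit in this assay, > 100000 nM. The step that the two limits leave unreadable from compound 1 to compound 2 therefore cannot be read, since (the limit of > 100000 nM in this assay, at which 2 of the 2 values shown sit). Compound 3 `C=CC1=C(C(=O)O)C(c2ccc(OC)c(OC)c2)OC1` differs from compound 2 by hydroxy in place of (4-chlorobenzyl)amino on a carbonyl carbon. Among the compounds with values here, no measured step bears on this change, and the two limits give no direction. Compound 3 is thus expected to remain at the limit in this assay, a step that the limit leaves unreadable from compound 2 to compound 3, with an estimate of 200000 nM (range 100000 nM to 1000000 nM).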

Compound 3, half-maximal inhibitory concentration: 18000 nM
Beside the measured number, compound 3's estimate is 11-fold (1.05 log units) above it; the whole stated range lies above it.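

Within the data shown here, at the carbonyl carbon, the move from amide to free acid is the first change that brings a reading off the limit in this assay. Hydroxy in place of (4-chlorobenzyl)amino gives an at least 5.5-fold lower number from compound 2 to compound 3 (0.74 log units; beyond the scatter), and hydroxy in place of benzylamino gives an at least 5.5-fold lower number from compound 1 to compound 3 (0.74 log units; beyond the scatter). The step between the two amides still cannot be read: the limit of > 100000 nM in this assay, at which 2 of the 3 values shown sit.

The compounds shown leave open whether the change follows from the free acid itself or from the loss of the aromatic ring, as a methyl ester or a primary amide on this carbonyl carbon could tell.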